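The source may hold more compounds than are shown below. What is called first, only, known or untested is meant among the compounds shown, and "the series" means these compounds.

Measured so far: compound 1 `COc1ccc(-c2cc(-c3ccc(F)cc3)c(C#N)c(OC)n2)cc1` gives 1360 nM; compound 2 `COc1nc(-c2ccccc2)cc(-c2ccc(Cl)cc2)c1C#N` gives 252 nM; compound 3 `COCCOc1nc(-c2ccccc2)cc(-c2ccc(F)cc2)c1C#N` gives 123 nM.

In an assay on isolated protein for inhibition of sulfide:quinone oxidoreductase, mitochondrial (Homo sapiens) (on this read-out lower numbers stand for stronger inhibition and higher numbers for weaker inhibition), compound 1 gives 1360 nM, the highest of the three numbers, with compound 2 and compound 3 both below it by more than the scatter. Compound 4 `COc1nc(-c2ccncc2)cc(-c2ccc(F)cc2)c1C#N` is not yet measured; against compound 1 the change is pyridin-4-yl in place of 4-methoxyphenyl on an aromatic carbon. Among the compounds with values here, no measured pair isolates this position, since compound 2 and compound 3 also differ from compound 1 elsewhere, so the size of the step is uncertain. Both of those lower numbers carry an unsubstituted phenyl there, and a step of about a 2.3-fold lower number from compound 1 to compound 4 (0.36 log units; beyond the scatter) toward a lower number is expected. For compound 4 the estimate is 600 nM, in the range 150 nM to 2500 nM.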

Compound 4, half-maximal inhibitory concentration: 17400 nM
Estimate against measurement, compound 4: 29-fold (1.46 log units) below; the measured number lies above the stated range.
By their numbers in this assay, from the lowest: compound 3; then compound 2; then compound 1; then compound 4.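

In this assay, within the data shown here, pyridin-4-yl in place of 4-methoxyphenyl gives a 13-fold higher number from compound 1 to compound 4 (1.11 log units; beyond the scatter), the only single-place reading at this position so far. The group on this aromatic carbon next to the ring nitrogen therefore matters, and the size of the step is large. Nothing at hand explains the step.

One step cannot separate the arrival of the ring nitrogen from the departure of the methoxy group. Pyridin-3-yl or 4-(dimethylamino)phenyl on the core of compound 1 would help separate these two changes.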